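Hydroxymethyl on the aromatic nitrogen: working notes on compound 3

The source may report more compounds than this note shows. Statements on the series, on what has been measured and on what is new or still open speak of the compounds shown alone.

Measured in a functional assay on TSGH cells (Homo sapiens) for inhibition, with a stated time of 72 h; on this read-out lower numbers stand for stronger inhibition and higher numbers for weaker inhibition:
- compound 1 `COc1cc(C(=O)c2ccc3[nH]ccc3c2)cc(OC)c1OC` gives 103 nM
- compound 2 `COc1cc(C(=O)c2ccc3c(ccn3C(C)C)c2)cc(OC)c1OC` gives 1100 nM

Within the data shown here, compound 2 holds the higher of the two numbers, which makes it the weaker inhibitor of the pair, and compound 1 is its only neighbour. Compound 3 `COc1cc(C(=O)c2ccc3c(ccn3CO)c2)cc(OC)c1OC` differs from compound 2 in one place, hydroxymethyl in place of isopropyl on an aromatic nitrogen on an aromatic nitrogen of a five-membered aromatic ring. Among the measured compounds shown here, one measured step bears on this change, at the same nitrogen: an 11-fold higher number from compound 1 to compound 2 (1.03 log units; beyond the scatter) with isopropyl in place of hydrogen, a large step beyond the scatter. For the measured compounds named here, no hydroxymethyl compound has been measured yet, so that step is the only guide. A moderate move toward a lower number in this assay is expected, recovering only part of that step. The expected step is a 3.1-fold lower number from compound 2 to compound 3 (0.50 log units; beyond the scatter) on this estimate. Compound 3 is estimated at 350 nM (expected range 100 nM to 1200 nM).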

Compound 3, half-maximal inhibitory concentration: 43 nM
For compound 3 the middle estimate is 8.1-fold (0.91 log units) above the measured one; the whole stated range lies above it.
By their numbers in this assay, from the lowest: compound 3; then compound 1; then compound 2.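

In this assay, substitution on the aromatic nitrogen does not by itself weaken inhibition: an 11-fold higher number from compound 1 to compound 2 (1.03 log units; beyond the scatter) held for isopropyl, but hydroxymethyl gives a 2.4-fold lower number from compound 1 to compound 3 (0.38 log units; beyond the scatter) and so goes below the value of the compound with hydrogen at this position. The outcome at this nitrogen therefore depends on the group placed there, and exchanging isopropyl for hydroxymethyl gives a 26-fold lower number from compound 2 to compound 3 (1.41 log units; beyond the scatter) as the largest step in this small set. Nothing available accounts for this difference between the two groups. 

Hydroxymethyl differs from isopropyl in both heavy atoms and hydrogen-bond donors and acceptors, so this single pair cannot show which difference matters. Methyl, methoxymethyl, aminomethyl and the longer hydroxyethyl chain would each help to separate these features, and the compounds shown say nothing about any of them.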